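Replacing the Cyano Group on a Shared Core

A few compounds are considered here, and "the series" means these few. Any claim that something is new, unique, unknown or untested is made for them only; others in the source may bear on it.

Of the compounds shown here, two built on one shared core have been tested in a functional assay on L1210 cells (Mus musculus) for inhibition; a higher number here means a weaker inhibitor, a lower number a stronger inhibitor. Compound 1 `N#Cc1cn([C@H]2C[C@H](O)[C@@H](CO)O2)c2ncnc(N)c12` gives 80000 nM in this assay . Compound 2 `N#Cc1cn(C2OC(CO)CC2O)c2ncnc(N)c12` gives 100 nM, the lowest of the two numbers, and its gap to compound 1 lies beyond the usual scatter. Compound 3 `NC(=S)c1cn(C2OC(CO)CC2O)c2ncnc(N)c12`, not yet measured, differs from compound 2 by a group of 3 heavy atoms (1 carbon, 1 nitrogen, 1 sulfur; no ring) in place of a group of 2 heavy atoms (1 carbon, 1 nitrogen; no ring), on an aromatic carbon. Within the data shown here, no measured pair shows a step of this kind, so the expected step of a 1.2-fold higher number from compound 2 to compound 3 (0.08 log units; within the scatter) is small, not beyond the scatter in either direction. Compound 3 is therefore estimated at 120 nM, within 25 nM to 600 nM.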

Compound 3, half-maximal inhibitory concentration: 600 nM
Estimate against measurement, compound 3: 5.0-fold (0.70 log units) below; low and high end bracket the measured number.
By their numbers in this assay, from the lowest: compound 2; then compound 3; then compound 1.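

Among these compounds, this is the first measured change at this aromatic carbon: with cyano replaced by a group of 3 heavy atoms (1 carbon, 1 nitrogen, 1 sulfur), this assay records a 6.0-fold higher number from compound 2 to compound 3 (0.78 log units; beyond the scatter). The number at this position therefore responds to the group placed there, although the step is modest. No measurement shown here offers an explanation for the step. The new group differs from cyano in more than one way, and a single pair cannot separate the sulfur from the hydrogen-bond donor. Going by these compounds, whether a carboxamide, a carboxylic acid or an aminomethyl group here would bring the number closer to that of compound 2 remains open.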